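This account rests on a few compounds, and the source may have more. Where it says the series, first, only, none or still open, it means among the compounds named here.

Measured so far:
compound 1 `Oc1cccc(-c2cc(-c3ccc(Cl)cc3)nc(-c3ccco3)c2)c1`, 10200 nM
compound 2 `Oc1cccc(-c2cc(-c3ccc(Cl)cc3)nc(-c3ccccn3)c2)c1`, 13500 nM

Both values come from a functional assay on HCT-15 cells (Homo sapiens) for cytotoxicity, read by CCK-8 assay and cell counting, with a stated time of 2 days; a lower number here means a stronger inhibitor, a higher number a weaker inhibitor. Among the compounds with values here, compound 2 holds the highest of the two numbers; its nearest neighbour is compound 1, and the one measured step, a 1.3-fold higher number from compound 1 to compound 2 (0.12 log units; within the scatter), is within the scatter, so the two compounds cannot be ordered.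

Compound 3 `Oc1cccc(-c2cc(-c3ccc(Cl)cc3)nc(-c3ccsc3)c2)c1` is not yet measured. It differs from compound 2 in one place: thiophen-3-yl in place of pyridin-2-yl on an aromatic carbon. Within the data shown here, the only step that bears on this change is the exchange at the same position of a five-membered ring for a six-membered one, a 1.3-fold higher number from compound 1 to compound 2 (0.12 log units; within the scatter), which was within the scatter. The reverse direction, a five-membered ring entering, is therefore expected to give at most a small step, if any, in this assay.

Compound 3 is expected to give 10500 nM, with a range from 4500 nM to 25000 nM, an expected step of a 1.3-fold lower number from compound 2 to compound 3 (0.11 log units; within the scatter).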

Compound 3, half-maximal inhibitory concentration: 8850 nM
Estimate against measurement, compound 3: 1.2-fold (0.07 log units) above; the range from low to high includes it.
By their numbers in this assay, from the lowest: compounds 3, 1 and 2 (each within the scatter of the next).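

In this assay, placing thiophen-3-yl on the aromatic carbon next to the ring nitrogen gives a 1.5-fold lower number from compound 2 to compound 3 (0.18 log units; within the scatter) and a 1.2-fold lower number from compound 1 to compound 3 (0.06 log units; within the scatter), so furan-2-yl, pyridin-2-yl and thiophen-3-yl cannot be ordered at this position. Across these three compounds, neither the size of the aromatic ring nor its hetero atom separates the numbers, which extends the single earlier comparison to a third ring. No measurement is available that would explain why these values stay so close.

Going by these compounds, whether an amine, a carboxylic acid or a longer chain at this position would move the number beyond the scatter remains open. All three compounds also keep the 3-hydroxyphenyl and 4-chlorophenyl groups, so what changes at those two places would do in this assay is likewise unresolved.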